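Capping the free ring nitrogen of compound 2

The source may report more compounds than this note shows. Statements on the series, on what has been measured and on what is new or still open speak of the compounds shown alone.

In an ADME assay on J774.A1 cells (Mus musculus) for cytotoxicity (on this read-out higher numbers stand for lower toxicity in this test and lower numbers for higher toxicity in this test), compound 1 `COc1ccc(-c2nc(N3CCNCC3)nc3ccccc23)c(OC)c1` gives 3.98 ug/mL and compound 2 `c1ccc2c(c1)ccn2-c1nc(N2CCNCC2)nc2ccccc12` gives 3.11 ug/mL so these two stand within the usual scatter of each other. Both carry a hydrogen on the amine nitrogen of their six-membered non-aromatic ring. Compound 3 `COc1cc(OC)c(-c2nc(N3CCN(C)CC3)nc3ccccc23)c(OC)c1` has a methyl group on that nitrogen and also differs elsewhere, and its reading of > 100 ug/mL is a limit of the assay and not a number.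

Compound 4 `c1ccc(N2CCN(c3nc(-n4ccc5ccccc54)c4ccccc4n3)CC2)nc1` has not been measured yet. Among the compounds with values here, it is compound 2 with pyridin-2-yl in place of hydrogen on an amine nitrogen in a ring as the only change. Within the data shown here, no measured pair differs in just one place, so any forecast is loose. Resting on compound 3 with its limit of > 100 ug/mL as the only guide, a moderate rise in this assay is expected, which would mean lower toxicity. The estimate is a 3.9-fold higher number from compound 2 to compound 4 (0.59 log units; beyond the scatter) as the expected step. For compound 4 the estimate is 12 ug/mL with an expected range of 4 ug/mL to 50 ug/mL around it.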

Compound 4, half-maximal cytotoxic concentration: 1.35 ug/mL
The estimate for compound 4 lay 8.9-fold (0.95 log units) above the measured number, and the stated range ends above it.
By their numbers in this assay, from the lowest: compound 4; then compounds 2 and 1 (each within the scatter of the next). At a limit, above all of these: compound 3.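

Within the data shown here, this is the first step in this assay that changes one place only, and putting pyridin-2-yl in place of hydrogen on the amine nitrogen in the ring gives a 2.3-fold lower number from compound 2 to compound 4 (0.36 log units; beyond the scatter) and so a modest rise in toxicity in this test. Capping this nitrogen with an aromatic ring therefore does not by itself lower toxicity in this test. Compound 3 also carries a group on that nitrogen but differs elsewhere as well, so it cannot be set against this step, and its reading is a limit and not a number: the limit of > 100 ug/mL in this assay, at which 1 of the 4 values shown sits.

Still open, going by these compounds, is whether another cap on this nitrogen, such as an acetyl group or a chain ending in a carboxylic acid, would move the number the other way. Also open, on these data alone, is whether pyridin-2-yl would give a similar step on compound 1.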